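This account rests on a few compounds, and the source may have more. Where it says the series, first, only, none or still open, it means among the compounds named here.

Compound 1 `COC(=O)c1c(Nc2ccccc2)sc(C(=O)c2ccc(OC)cc2)c1C` gives 28.6% in a functional assay, with a stated time of 150 min, tested at 15 ug/mL (on this read-out lower numbers stand for a weaker effect and higher numbers for a stronger effect at the one concentration tested), the highest of the two numbers measured. Compound 2 `COC(=O)c1c(Nc2ccc(OC)cc2)sc(C(=O)c2ccc(OC)cc2)c1C` carries a methoxy in place of hydrogen on an aromatic carbon and gives 7.8%, a step of a number 20.8 percentage points lower from compound 1 to compound 2 (beyond the scatter). Compound 3 `COC(=O)c1c(Nc2ccc(Cl)cc2)sc(C(=O)c2ccc(OC)cc2)c1C` is reported as "not active" (no number reported) in this assay, with no number given. Compound 4 `COc1ccc(C(=O)c2sc(Nc3ccccc3)c(C(=O)O)c2C)cc1` differs from compound 1 at another place: hydrogen in place of methyl on an oxygen next to a carbonyl group, so that the methoxycarbonyl becomes a carboxy. Within the data shown here, the one measured step concerns the ring on the nitrogen, not this oxygen, so no measured step bears on this change and the outcome is open. Compound 4 is estimated at 15%, between 0% and 40%, which means an expected a number 13.6 percentage points lower from compound 1 to compound 4 (beyond the scatter).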

Compound 4, a percentage reported as activity, at one concentration (the size of the read-out at that concentration, not a potency): 36.5%
For compound 4 the middle estimate is 21.5 percentage points below the measured one, within the range that was stated.
By their numbers in this assay, from the lowest: compound 2; then compounds 1 and 4 (each within the scatter of the next).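

Methoxycarbonyl and carboxy cannot be told apart in this assay (a number 7.9 percentage points higher from compound 1 to compound 4 (within the scatter)). The methyl on this oxygen is therefore not needed for the effect of compound 1, and a free carboxy is tolerated at this place on the shared core. Nothing measured here explains why this swap leaves so little mark.

On these data alone, whether an amide or an ethyl ester would read the same at this place stays open. So does whether the carboxy would read the same in compound 2, which carries a methoxy on the ring on the nitrogen.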